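Amide nitrogen substitution in a TRPM8 agonist series

The compounds below may be only part of what the source reports. "The series", "measured", "known", "first", "only" and "open" are said of these compounds alone.

Measured so far:
- compound 1 `Cc1ccc(OCC(=O)N(Cc2cccs2)c2ncco2)cc1`: 0.3 nM
- compound 2 `CCN(Cc1cccn1C)C(=O)COc1ccc(C)cc1`: 21300 nM
- compound 3 `CCN(Cc1cccs1)C(=O)c1cc2cc(C)ccc2n1C`: "not active" (no number reported)

In an assay on HEK293 cells for agonist activity at transient receptor potential cation channel subfamily M member 8 (Homo sapiens), read by fluorescence and calcium flux, with a stated time of 15 min (on this read-out lower numbers stand for an effect already at smaller amounts and higher numbers for an effect only at larger amounts of compound), compound 1 gives 0.3 nM, the lowest number of the two reported, and stands far apart from compound 2, which gives 21300 nM; that gap is well beyond the scatter. Compound 3, with a different core, is reported only as "not active" (no number reported) with no number.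

Compound 4 `COCCN(Cc1cccs1)C(=O)COc1ccc(C)cc1` is yet to be measured in this assay. Its change from compound 1 is 2-methoxyethyl in place of 1,3-oxazol-2-yl on an amide-type nitrogen. Among the compounds with values here, no single-point step between measured compounds exists for this change, so the expectation rests on the spread seen in compound 2, where the loss of the 1,3-oxazol-2-yl was part of a much larger drop to 21300 nM. A large upward step is expected for compound 4, a 5000-fold higher number from compound 1 to compound 4 (3.70 log units; beyond the scatter), though smaller than the whole gap to compound 2 since the thiophen-2-ylmethyl side is retained.

Compound 4 is therefore estimated at 1500 nM, within a range of 100 nM to 20000 nM.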

Compound 4, half-maximal effective concentration: 400 nM
For compound 4 the middle estimate is 3.8-fold (0.57 log units) above the measured one, within the range that was stated.
By their numbers in this assay, from the lowest: compound 1; then compound 4; then compound 2.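

In this assay this amide-type nitrogen responds strongly to a single change: 2-methoxyethyl in place of 1,3-oxazol-2-yl gives a 1300-fold higher number from compound 1 to compound 4 (3.12 log units; beyond the scatter) with the rest of the structure unchanged. Within the data shown here, it is the only step that isolates this substituent, since the earlier compounds offered no pair differing in one place. Compound 4 still gives a number, 400 nM on this read-out, so a ring on this nitrogen is not required for a measurable response. No measurement at hand accounts for the size of this step.

Still open, as far as these compounds go, is whether the step follows from the loss of the ring or from the 2-methoxyethyl chain itself. A 1,3-thiazol-2-yl group or a plain propyl chain on the same nitrogen would separate these two readings.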